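A few compounds are considered here, and "the series" means these few. Any claim that something is new, unique, unknown or untested is made for them only; others in the source may bear on it.

Compound 1 `CCC(C(=O)NCc1ccc(C(F)(F)F)nc1N1CCC(C)CC1)c1ccc(NS(C)(=O)=O)c(F)c1` gives 1.6 nM in an assay on CHO cells for antagonist activity at transient receptor potential cation channel subfamily V member 1 (Homo sapiens), read by FLIPR; a lower number here means a stronger inhibitor, a higher number a weaker inhibitor.
Compound 2 `CC1CCN(c2nc(C(F)(F)F)ccc2CNC(=O)C(c2ccc(NS(C)(=O)=O)c(F)c2)C2CCCC2)CC1` gives 88.7 nM in this assay.
Compound 3 `CS(=O)(=O)Nc1ccc(C(C(=O)NCc2ccc(C(F)(F)F)nc2SC2CCCCC2)c2cccc(F)c2)cc1F` gives 48.7 nM in this assay.

Compound 1 has the lowest number of the three in this assay, so it is the strongest inhibitor among them, and both other compounds stand well beyond the scatter from it. Compound 4 `Cc1ccccc1C(C(=O)NCc1ccc(C(F)(F)F)nc1N1CCC(C)CC1)c1ccc(NS(C)(=O)=O)c(F)c1` has not yet been measured. Against compound 1 it carries one change: 2-methylphenyl in place of ethyl on a saturated chain carbon bound to an aromatic carbon and a carbonyl carbon. Going by the values given here, the one measured step at this same place is a 55-fold higher number from compound 1 to compound 2 (1.74 log units; beyond the scatter), where a larger saturated ring replaced the ethyl and potency fell sharply. Compound 3, which carries a fluorophenyl at that carbon but also differs elsewhere in the core, gives a number far above compound 1 as well. Both observations point the same way: a bulkier group on this chain carbon has so far gone with weaker inhibition. The 2-methylphenyl of compound 4 is larger than ethyl, so a loss is expected for compound 4, a 38-fold higher number from compound 1 to compound 4 (1.57 log units; beyond the scatter), in this assay. Compound 4 is therefore estimated at 60 nM, with a likely range from 15 nM to 250 nM.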

Compound 4, inhibition constant: 42.9 nM
Compound 4: the middle estimate sits 1.4-fold (0.15 log units) above what was measured, and the stated range covers the measured number.
By their numbers in this assay, from the lowest: compound 1; then compounds 4, 3 and 2 (each within the scatter of the next, the first and the last beyond it).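

Replacing ethyl with the aromatic 2-methylphenyl on this saturated chain carbon also costs heavily in this assay (a 27-fold higher number from compound 1 to compound 4 (1.43 log units; beyond the scatter)), so the loss seen with cyclopentyl is not limited to a saturated ring. All the single changes at this place now go the same way, with no compound shown against it: a ring in place of ethyl gives a weaker inhibitor. The two rings are not equivalent, though, as 2-methylphenyl recovers a modest part of the loss (a 2.1-fold lower number from compound 2 to compound 4 (0.32 log units; beyond the scatter)), and no measurement at hand explains either step.

As far as these compounds go, it remains open whether a longer chain such as propyl, or a smaller group such as methyl, would match or improve on ethyl at this carbon. A plain phenyl would show what the methyl on the aromatic ring contributes.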